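One Methyl More on the Benzyl Arm

This account rests on a few compounds, and the source may have more. Where it says the series, first, only, none or still open, it means among the compounds named here.

Compound 1, `CC(=O)OC[C@H]1O[C@@H](n2cc(-c3cn(Cc4ccc(C(C)C)cc4)nn3)c(=O)[nH]c2=O)C[C@@H]1OC(C)=O`, carries a 4-isopropylbenzyl group on its shared core. In a functional assay on MDA-MB-231 cells (Homo sapiens) for cytotoxicity, read by sulforhodamine B assay, tested at 10 uM (a lower number here means less inhibition, a higher number more inhibition at the concentration tested (going by the name of the read-out)), compound 1 gives 98.1%, which is the lower of the two values recorded so far. Compound 2, `CC(C)(C)c1ccc(-c2cc(-c3cn([C@H]4C[C@H](O)[C@@H](CO)O4)c(=O)[nH]c3=O)on2)cc1`, built on a different linker but the same core, reaches 102% in this assay; the two values lie within the usual scatter of each other, so the two numbers are level. Both numbers sit high on the scale of this assay at the tested concentration.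

Compound 3, `CC(=O)OC[C@H]1O[C@@H](n2cc(-c3cn(Cc4ccc(C(C)(C)C)cc4)nn3)c(=O)[nH]c2=O)C[C@@H]1OC(C)=O`, differs from compound 1 in one place: methyl in place of hydrogen on a saturated chain carbon bound to an aromatic carbon and two saturated chain carbons. Read one bond further out, this turns 4-isopropylbenzyl into 4-(tert-butyl)benzyl.

Among the measured compounds shown here, no measured pair yet shows what this change does. Since compound 1 already sits near the top of the scale, compound 3 is expected to land at about 98%, between 88% and 105%. The expected step of a number 0.1 percentage points lower from compound 1 to compound 3 (within the scatter) is thus none beyond the scatter.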

Compound 3, a percentage reported as inhibition, at one concentration (the size of the read-out at that concentration, not a potency): 105%
Compound 3: middle estimate off by 7 percentage points, on the low side; low and high end bracket the measured number.
By their numbers in this assay, from the lowest: compounds 1, 2 and 3 (each within the scatter of the next).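

Turning 4-isopropylbenzyl into 4-(tert-butyl)benzyl gives, in this assay, a number 6.9 percentage points higher from compound 1 to compound 3 (within the scatter). Among the compounds shown here, this is the first measured pair that differs in one place, and it shows that methyl in place of hydrogen on this saturated chain carbon leaves the read-out level. Both compounds sit high on the scale at the single tested concentration, so a difference in potency could stay hidden, and no measurement at hand explains the outcome.

As far as these compounds go, it remains open whether an amine or a carboxylic acid in place of the tert-butyl group would bring the number down. Also open, from the compounds shown here alone, is how far compound 1 and compound 3 would stand apart at a lower concentration, where the read-out might no longer sit near the top of the scale.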